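The compounds below may be only part of what the source reports. "The series", "measured", "known", "first", "only" and "open" are said of these compounds alone.

Compound 1 `CNc1ncc2c(-c3ccc(N4CCNCC4)nc3)nn(CC3CCCC3)c2n1` carries, on the shared core, a six-membered non-aromatic ring with two nitrogens, one of them bearing a hydrogen. In an assay for inhibition of proto-oncogene tyrosine-protein kinase receptor Ret (Homo sapiens), read by 33P incorporation, in the presence of a further agent that is not named here (on this read-out higher numbers stand for weaker inhibition and lower numbers for stronger inhibition), compound 1 gives 50 nM. Compound 2 `CNc1ncc2c(-c3ccc(N4CCN(C)CC4)nc3)nn(CC3CCCC3)c2n1` has a methyl on that ring nitrogen instead, and in this assay compound 2 gives 60 nM. The step of a 1.2-fold higher number from compound 1 to compound 2 (0.08 log units; within the scatter) is therefore a change too small to count. Among the two compounds measured, compound 2 has the higher number, but its only neighbour, compound 1, sits within the scatter of it, so nothing separates them. Compound 3 `CNc1ncc2c(-c3ccc(N4CCN(C(=O)C(C)(C)C)CC4)nc3)nn(CC3CCCC3)c2n1` goes one step further: (tert-butyl)carbonyl in place of methyl on an amine nitrogen in a ring. For the measured compounds named here, the only measured step that bears on this, a 1.2-fold higher number from compound 1 to compound 2 (0.08 log units; within the scatter), was within the scatter, yet it exchanged one small group for another, whereas compound 3 brings in a larger group. A modest weakening, a 2.0-fold higher number from compound 2 to compound 3 (0.30 log units; within the scatter), is expected for compound 3, estimated at 120 nM with a range from 40 nM to 400 nM.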

Compound 3, half-maximal inhibitory concentration: > 10000 nM
Compound 3: no number, only a limit (the forecaster's own chance of this, stated with the estimate: 5%); at least 83-fold (1.92 log units) between middle value and limit.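

In this assay compound 3 gives only a limit of the assay, not a number: the limit of > 10000 nM in this assay, at which 1 of the 3 values shown sits. Replacing methyl with (tert-butyl)carbonyl on this ring nitrogen gives an at least 160-fold higher number from compound 2 to compound 3 (2.22 log units; beyond the scatter), and replacing hydrogen with the same group gives an at least 200-fold higher number from compound 1 to compound 3 (2.30 log units; beyond the scatter). The swap of hydrogen for methyl gave no sign of it, but these large steps show that the group on this nitrogen can decide whether inhibition is seen at all in this assay.

The change brings in a carbonyl and a tert-butyl together, and the compounds shown do not tell which of the two matters. An acetyl group, which keeps the carbonyl without the tert-butyl, and a tert-butyl placed directly on the nitrogen, which keeps it without the carbonyl, would pull the two apart.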